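The source may hold more compounds than are shown below. What is called first, only, known or untested is meant among the compounds shown, and "the series" means these compounds.

Measured in a functional assay on SW-620 cells (Homo sapiens) for cytotoxicity, read by sulforhodamine B assay, with a stated time of 48 h; a lower number here means a stronger inhibitor, a higher number a weaker inhibitor:
compound 1 `COc1ccc(C2=NO[C@]3(C2)C(=O)O[C@@H]2[C@H]3CC[C@H](C)[C@]3(O)C=CC(=O)[C@@]23C)cc1` gives 41000 nM
compound 2 `C[C@H]1CC[C@@H]2[C@@H](OC(=O)[C@]23CC(c2ccc(N(C)C)cc2)=NO3)[C@]2(C)C(=O)C=C[C@@]12O` gives 5100 nM
compound 3 `C[C@H]1CC[C@@H]2[C@@H](OC(=O)[C@]23CC(c2ccccc2[N+](=O)[O-])=NO3)[C@]2(C)C(=O)C=C[C@@]12O` gives 40000 nM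

Compound 1 stands highest of the three numbers in this assay; nearest is compound 3, with a 1.0-fold lower number from compound 1 to compound 3 (0.01 log units; within the scatter), furthest compound 2, with an 8.0-fold lower number from compound 1 to compound 2 (0.91 log units; beyond the scatter). Between the other two lies a 7.8-fold higher number from compound 2 to compound 3 (0.89 log units; beyond the scatter).

Compound 4 `C[C@H]1CC[C@@H]2[C@@H](OC(=O)[C@]23CC(c2ccccc2F)=NO3)[C@]2(C)C(=O)C=C[C@@]12O` differs from compound 1 in one place: 2-fluorophenyl in place of 4-methoxyphenyl on a carbon with a double bond to nitrogen. The step that bears on it is a 1.0-fold lower number from compound 1 to compound 3 (0.01 log units; within the scatter), where another group replaced 4-methoxyphenyl on the carbon with a double bond to nitrogen without moving the number beyond the scatter. Among the measured compounds shown here, the only step beyond the scatter, an 8.0-fold lower number from compound 1 to compound 2 (0.91 log units; beyond the scatter), concerns a different change and gives no guide here. Compound 4 is therefore expected to show no step beyond the scatter, a 1.2-fold lower number from compound 1 to compound 4 (0.07 log units; within the scatter). The estimate for compound 4 is 35000 nM, within 15000 nM to 80000 nM.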

Compound 4, half-maximal inhibitory concentration: 11000 nM
The estimate for compound 4 lay 3.2-fold (0.50 log units) above the measured number; measured number outside the range, below it.
By their numbers in this assay, from the lowest: compound 2; then compound 4; then compounds 3 and 1 (each within the scatter of the next).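

In this assay, replacing 4-methoxyphenyl at this carbon with a double bond to nitrogen is not always silent: 2-fluorophenyl gives a 3.7-fold lower number from compound 1 to compound 4 (0.57 log units; beyond the scatter), whereas 2-nitrophenyl stayed within the scatter. The group on the aromatic carbon therefore matters, with fluoro in place of nitro giving a 3.6-fold lower number from compound 3 to compound 4 (0.56 log units; beyond the scatter), though 2-fluorophenyl does not match 4-(dimethylamino)phenyl, as a 2.2-fold higher number from compound 2 to compound 4 (0.33 log units; beyond the scatter) shows. No measurement available here accounts for these steps. Open, as far as these compounds go, is whether a chloro group or a primary amine in place of the fluoro would keep, lower or raise the number.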